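The source may report more compounds than this note shows. Statements on the series, on what has been measured and on what is new or still open speak of the compounds shown alone.

Measured compounds in an ADME assay on L02 cells (Homo sapiens) for cytotoxicity, read by MTT assay, with a stated time of 24 h; on this read-out higher numbers stand for weaker inhibition and lower numbers for stronger inhibition:

Compound 1 `O=C1/C(=C/c2ccccc2F)CN(S(=O)(=O)c2ccc(F)cc2)C/C1=C\c1ccccc1F` gives 17500 nM.
Compound 2 `O=C1/C(=C/c2ccccc2F)CN(S(=O)(=O)c2ccc(Cl)cc2)C/C1=C\c1ccccc1F` gives 14100 nM.
Compound 3 `O=C1/C(=C/c2cccc(F)c2)CN(S(=O)(=O)c2ccc(F)cc2)C/C1=C\c1cccc(F)c1` gives 21900 nM.

Compounds 1 and 2 share a core and differ in one place: chloro in place of fluoro on an aromatic carbon. In this assay this change made a 1.2-fold lower number from compound 1 to compound 2 (0.09 log units; within the scatter), so the two numbers cannot be told apart. Compound 3 carries the same atoms as compound 1 joined differently; the difference between the two cores is not broken down here. Its value in this assay sits with those of compound 1 and compound 2, all three within the scatter of one another.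

Compound 4 `O=C1/C(=C/c2cccc(F)c2)CN(S(=O)(=O)c2ccc(Cl)cc2)C/C1=C\c1cccc(F)c1` has not yet been measured. It stands to compound 3 as compound 2 stands to compound 1: chloro in place of fluoro on an aromatic carbon. The change occurs twice among these compounds, and its one measured instance is the step from compound 1 to compound 2. Because a 1.2-fold lower number from compound 1 to compound 2 (0.09 log units; within the scatter) was within the scatter, the step from compound 3 to compound 4 in this assay is expected to be of a similar size, a 1.2-fold lower number from compound 3 to compound 4 (0.09 log units; within the scatter). On that basis compound 4 is estimated to give 17600 nM, with a likely range from 9000 nM to 34000 nM.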

Compound 4, half-maximal inhibitory concentration: 15700 nM
For compound 4 the middle estimate is 1.1-fold (0.05 log units) above the measured one; measured number inside the range.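

In this assay, the exchange of 4-fluorophenyl for 4-chlorophenyl on the sulfonyl group gave a 1.4-fold lower number from compound 3 to compound 4 (0.14 log units; within the scatter), so on this core too the two numbers cannot be told apart. Set beside the earlier step, the change carries from one core to the other with no difference that can be detected: the same change on two cores in this assay, a 1.2-fold lower number (0.09 log units; within the scatter) from compound 1 to compound 2 and a 1.4-fold lower number (0.14 log units; within the scatter) from compound 3 to compound 4, 1.1-fold (0.05 log units) apart, within the scatter of two such steps This shows only that the exchange leaves the read-out within the scatter on these two cores; it does not establish that the change has a real effect of any size or direction, nor that it would behave the same way on other cores or in other assays.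

The compounds shown leave open how a group other than a halogen, such as a methoxy group, a nitrile or an amine, would read in this assay at this place on the ring. They also leave open whether the picture holds with chloro in place of fluoro on the other two aromatic rings.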